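The source may hold more compounds than are shown below. What is called first, only, known or untested is meant among the compounds shown, and "the series" means these compounds.

Two compounds of the series have been run in a functional assay on CHO-K1 cells for agonist activity at leukotriene B4 receptor 2 (Homo sapiens), read by HTRF and inositol phosphate accumulation, with a stated time of 90 min; on this read-out lower numbers stand for an effect already at smaller amounts and higher numbers for an effect only at larger amounts of compound. Compound 1 `CCCCC1=NC2(CCCC2)C(=O)N1Cc1ccc(-c2ccccc2C(=O)O)cc1` gives 1490 nM. Compound 2 `CCCCC1=NC(C)(C(C)C)C(=O)N1Cc1ccc(-c2ccccc2-c2nnn[nH]2)cc1` gives 67.6 nM, the lowest of the two numbers; compound 1 stands at a higher number, beyond the scatter. Compound 3 `CCCCC1=NC(C)(C)C(=O)N1Cc1ccc(-c2ccccc2-c2nnn[nH]2)cc1` is not yet measured and differs from compound 2 by methyl in place of isopropyl on a saturated ring carbon. Within the data shown here, no single-point step between measured compounds is available to anchor this change, so the expectation is a moderate loss, as the step of a 2.2-fold higher number from compound 2 to compound 3 (0.35 log units; beyond the scatter) expresses. For compound 3 the estimate in this assay is 150 nM, within 40 nM to 600 nM.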

Compound 3, half-maximal effective concentration: 8140 nM
Beside the measured number, compound 3's estimate is 54-fold (1.73 log units) below it; the whole stated range lies below it.
By their numbers in this assay, from the lowest: compound 2; then compound 1; then compound 3.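

Among these compounds, replacing isopropyl with methyl on this saturated ring carbon gives a 120-fold higher number from compound 2 to compound 3 (2.08 log units; beyond the scatter) in this assay, the first step that can be read at a single place. The result at this ring carbon depends strongly on which alkyl group it carries, although neither group has a hydrogen-bond donor, acceptor or net charge. No evidence bearing on the reason for this step is available.

Open, from the compounds shown here alone, is where ethyl or tert-butyl on this ring carbon would fall relative to compound 2 and compound 3. Going by these compounds, an amine there also remains open.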